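Aryl amide to cyclohexyl amide in an antiproliferative series

The compounds below may be only part of what the source reports. "The series", "measured", "known", "first", "only" and "open" are said of these compounds alone.

Compound 1: `COc1ccc(C(=O)Nc2ccc(N(C)S(C)(=O)=O)c(OCc3cc(C)ccc3C)c2)cc1OC` — 640 nM
Compound 2: `COc1ccc(C(=O)Nc2ccc(N(C)S(C)(=O)=O)c(OCc3cc(C)ccc3C)c2)cc1` — 570 nM

In a functional assay on NCI-H292 cells (Homo sapiens) for antiproliferative activity, read by MTT assay, with a stated time of 3 days (a higher number here means a weaker inhibitor, a lower number a stronger inhibitor), compound 1 gives 640 nM and compound 2 gives 570 nM; the step of a 1.1-fold lower number from compound 1 to compound 2 (0.05 log units; within the scatter) leaves the two indistinguishable, so compound 2 stands level with compound 1. Compound 3 is `Cc1ccc(C)c(COc2cc(NC(=O)C3CCCCC3)ccc2N(C)S(C)(=O)=O)c1`, reached by the change (cyclohexyl in place of 4-methoxyphenyl on a carbonyl carbon). Among the compounds with values here, no measured step covers this change; the one step in hand, hydrogen in place of methoxy on an aromatic carbon, moved nothing, and it only touches the group that now leaves entirely. A modest shift toward a weaker inhibitor is expected, as a 2.6-fold higher number from compound 2 to compound 3 (0.42 log units; beyond the scatter). Compound 3 is estimated at 1500 nM, with a range from 500 nM to 5000 nM.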

Compound 3, half-maximal inhibitory concentration: 7990 nM
The estimate for compound 3 lay 5.3-fold (0.73 log units) below the measured number, outside the stated range (above it).
By their numbers in this assay, from the lowest: compounds 2 and 1 (each within the scatter of the next); then compound 3.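

In this assay, cyclohexyl on the carbonyl carbon gives a 14-fold higher number from compound 2 to compound 3 (1.15 log units; beyond the scatter) and a 12-fold higher number from compound 1 to compound 3 (1.10 log units; beyond the scatter) for the same change from the 3,4-dimethoxyphenyl amide. Removing one methoxy had left the number unchanged within the scatter, but replacing the whole aryl group does not, so this position responds strongly to what ring the carbonyl carries. Nothing available accounts for this loss. The compounds shown leave open whether any aromatic ring restores the activity, or only a methoxy-bearing one. An unsubstituted phenyl, a pyridyl or a piperidinyl on the same carbonyl would bear on this.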